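Methoxy for Methyl on the Benzyl Group of Compound 1

This account rests on a few compounds, and the source may have more. Where it says the series, first, only, none or still open, it means among the compounds named here.

Compound 1 `COC(=O)/C=C/c1ccc2c(c1)C(=O)C(=O)N2Cc1ccc(C)cc1` was tested in a functional assay on HT-29 cells (Homo sapiens) for cytotoxicity, read by MTT assay, with a stated time of 48 h (a lower number here means a stronger inhibitor, a higher number a weaker inhibitor), where compound 1 gives 30 nM. Of the two compounds that yielded a number in this assay, compound 1 has the lowest; the nearest is compound 2 `COC(=O)/C=C/c1ccc2c(c1)C(=O)C(=O)N2Cc1ccc2ccccc2c1`, which in this assay gives 100 nM, a gap beyond the usual scatter. A third, smaller compound, compound 3 `CCCCc1ccc2c(c1)C(=O)C(=O)N2`, was also tested; in this assay compound 3 reaches only > 10000 nM, which is a limit of the assay and not a number (the limit of > 10000 nM in this assay, at which 1 of the 3 values shown sits).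

The unmeasured compound 4 `COC(=O)/C=C/c1ccc2c(c1)C(=O)C(=O)N2Cc1ccc(OC)cc1` differs from compound 1 in one place: methoxy in place of methyl on an aromatic carbon. Among the measured compounds shown here, no pair of measured compounds differs in exactly this way, so the measured numbers say nothing direct about it. The two measured numbers come from compounds whose groups on the ring nitrogen differ far more than methyl and methoxy do, and even that larger difference moved the number only modestly.

The step expected a 1.3-fold higher number from compound 1 to compound 4 (0.12 log units; within the scatter) is therefore small, most likely within the scatter, with no clear direction. Compound 4 is estimated at 40 nM, with a range from 15 nM to 120 nM.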

Compound 4, half-maximal inhibitory concentration: 30 nM
Beside the measured number, compound 4's estimate is 1.3-fold (0.12 log units) above it; the measured number falls inside the stated range.
By their numbers in this assay, from the lowest: compounds 1 and 4 (each within the scatter of the next); then compound 2. At a limit, above all of these: compound 3.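

Methoxy in place of methyl on an aromatic carbon reads in this assay as no change at the digits printed from compound 1 to compound 4 (within the scatter), and this is the first step shown that isolates a single place, since the earlier compounds offered no such pair. It shows that at this carbon, para to a large group, going from 4-methylphenyl to 4-methoxyphenyl adds an oxygen and a hydrogen-bond acceptor with no difference beyond the scatter, which the gap between the two earlier numbers, from compounds differing far more on the ring nitrogen, could not say. Nothing shown here gives a cause for this outcome.

What the compounds shown leave open is whether this holds only for groups as close to methyl as methoxy, or also for an amine, a carboxylic acid or a longer alkoxy chain at the same carbon. On these data alone, it is also open whether methoxy would read the same on another carbon of that ring, since one step at one place cannot speak for the rest of the ring.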